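Inverting the Ring Stereocentre of Compound 2

The source may report more compounds than this note shows. Statements on the series, on what has been measured and on what is new or still open speak of the compounds shown alone.

Measured compounds:
Compound 1 `Cc1c(CO)cc2n1[C@@H](c1ccccc1)SC2`: 26400 nM
Compound 2 `Cc1c(CO)c(CO)c2n1[C@@H](c1ccccc1)SC2`: 12200 nM
Compound 3 `OCc1c(CO)c(-c2ccccc2)n2c1CS[C@@H]2c1ccccc1`: 92600 nM

In a functional assay on MCF7 cells (Homo sapiens) for cytotoxicity, read by MTT assay, with a stated time of 24 h (on this read-out higher numbers stand for weaker inhibition and lower numbers for stronger inhibition), compound 2 holds the lowest number of the three. Its neighbours sit on either side of it by steps that are both beyond the scatter: a 2.2-fold lower number from compound 1 to compound 2 (0.34 log units; beyond the scatter), and a 7.6-fold higher number from compound 2 to compound 3 (0.88 log units; beyond the scatter). Compound 4 `Cc1c(CO)c(CO)c2n1[C@H](c1ccccc1)SC2` has not been measured in this assay. Compared with compound 2, (the two compounds have the same atoms and bonds and differ only in configuration as drawn: 1 of 1 stereo elements differ; a stereocentre at a saturated ring carbon is drawn R in compound 2 and S in compound 4). Neither measured step bears on this change: one step adds a hydroxymethyl on an aromatic carbon, the other exchanges methyl for phenyl on an aromatic carbon, and both alter atoms rather than configuration as drawn. Nothing among the three measured compounds shows what inversion at the saturated ring carbon does. Compound 4 is therefore expected to sit near compound 2, with an expected step of a 1.3-fold higher number from compound 2 to compound 4 (0.12 log units; within the scatter) and a wide range on either side. The estimate for compound 4 in this assay is 16000 nM, expected to fall between 5000 nM and 60000 nM.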

Compound 4, half-maximal inhibitory concentration: 1750 nM
The estimate for compound 4 lay 9.1-fold (0.96 log units) above the measured number; measured number below the stated range.
By their numbers in this assay, from the lowest: compound 4; then compound 2; then compound 1; then compound 3.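

In this assay, the stereocentre at a saturated ring carbon proves to be a position where configuration alone moves the number, with a 7.0-fold lower number from compound 2 to compound 4 (0.84 log units; beyond the scatter). The earlier steps shown here changed only groups on aromatic carbons, and this inversion, with no atom added or removed, is larger than the hydroxymethyl step, a 2.2-fold lower number from compound 1 to compound 2 (0.34 log units; beyond the scatter). The step belongs to that stereocentre alone, and the ground for this is: the fact that compounds 2 and 4 differ only in the configuration as drawn.

Among these compounds, only this one pair separates the two configurations, so it remains open whether inversion would lower the number in the same way for the cores of compound 1 and compound 3. Going by these compounds, it is also open how either configuration would fare with an amine or a carboxylic acid in place of hydroxymethyl on the aromatic carbon.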